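The source may hold more compounds than are shown below. What is called first, only, known or untested is meant among the compounds shown, and "the series" means these compounds.

Series notes, tolerability. Compound 1 `Cc1cc(CCC#N)cc(C)c1Oc1cc(Nc2ccc(C#N)cc2)c(N)cc1C(F)(F)F` is the reference. In an ADME assay on TZM cells (Homo sapiens) for cytotoxicity, read by XTT assay, with a stated time of 4 days (a lower number here means that less compound is tolerated, a higher number that more compound is tolerated), compound 1 gives only a limit of the assay, > 7100 nM, and no number. Compound 2 `Cc1cc(/C=C/C#N)cc(C)c1Oc1cc(Nc2ccc(C#N)cc2)c(N)cc1C(F)(F)F` carries 2-cyanoethenyl in place of 2-cyanoethyl; in this assay compound 2 gives 15000 nM. The step that the limit leaves unreadable from compound 1 to compound 2 is not readable. Compound 1 stands only as the limit of > 7100 nM in this assay, at which 1 of the 2 values shown sits; that is what leaves the step unreadable. Compound 3 `Cc1cc(CCC#N)cc(C)c1Oc1cc(Nc2ccc(C#N)cc2)c(N)cc1C(=O)O` changes the core instead: carboxy in place of trifluoromethyl on an aromatic carbon. Going by the values given here, no measured step touches the trifluoromethyl position, and the one step recorded is unreadable, so the series sets no size and no direction for compound 3 in this assay. The values recorded are large, and compound 3 is expected to behave alike. The estimate for compound 3 in this assay is 15000 nM, within 7000 nM to 40000 nM. The expected step that the limit leaves unreadable from compound 1 to compound 3 is within the scatter. A further limit rather than a number for compound 3 is expected to be quite possible.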

Compound 3, half-maximal cytotoxic concentration: 14300 nM
The estimate for compound 3 lay 1.0-fold (0.02 log units) above the measured number, and the stated range covers the measured number.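

The step from compound 1 to compound 3 cannot be read, because compound 1 stands only as a limit and not a number: the limit of > 7100 nM in this assay, at which 1 of the 3 values shown sits.

The compounds shown leave open the size and direction of the effect of carboxy in place of trifluoromethyl in this assay.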